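From piperidin-1-yl to morpholin-4-yl on the carbonyl carbon

The compounds below may be only part of what the source reports. "The series", "measured", "known", "first", "only" and "open" are said of these compounds alone.

Within the data shown here, in a functional assay on MCF7 cells (Homo sapiens) for antiproliferative activity, read by sulforhodamine B assay, with a stated time of 48 h (on this read-out higher numbers stand for weaker inhibition of growth and lower numbers for stronger inhibition of growth), compound 2 `CCCCCCCC/C=C\CCCCCCCC(=O)N1CCCCC1` gives 7.6 ug/mL, the lower of the two numbers so far. The other number belongs to compound 1 `CCCCCC[C@@H](O)C/C=C\CCCCCCCC(=O)N1CCOCC1`, at 41.8 ug/mL, a gap beyond the usual scatter. Compound 3 `CCCCCCCC/C=C\CCCCCCCC(=O)N1CCOCC1` has morpholin-4-yl in place of piperidin-1-yl on a carbonyl carbon. Among the measured compounds shown here, no measured step isolates this change. For the measured compounds named here, the only measured compound bearing morpholin-4-yl is compound 1, at 41.8 ug/mL, so a moderately higher number is expected in this assay. The estimated step is a 2.1-fold higher number from compound 2 to compound 3 (0.32 log units; beyond the scatter). For compound 3 the expected value is 16 ug/mL, within a range of 6 ug/mL to 40 ug/mL.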

Compound 3, concentration for 50% growth inhibition: 4.9 ug/mL
For compound 3 the middle estimate is 3.3-fold (0.51 log units) above the measured one; the whole stated range lies above it.
By their numbers in this assay, from the lowest: compounds 3 and 2 (each within the scatter of the next); then compound 1.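

In this assay, morpholin-4-yl in place of piperidin-1-yl on the carbonyl carbon gives a 1.6-fold lower number from compound 2 to compound 3 (0.19 log units; within the scatter), so this exchange does not separate the two compounds. Hydrogen in place of hydroxy on the saturated chain carbon gives an 8.5-fold lower number from compound 1 to compound 3 (0.93 log units; beyond the scatter), so the high number of compound 1 does not go with morpholin-4-yl alone. No supporting measurement bears on the cause of either step.

Still open, from the compounds shown here alone, is whether hydroxy on that chain carbon has a similar effect with piperidin-1-yl on the carbonyl carbon. Also open, going by these compounds, is how a dimethylamino group or a piperazine ring would read there.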